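A few compounds are considered here, and "the series" means these few. Any claim that something is new, unique, unknown or untested is made for them only; others in the source may bear on it.

Among the compounds with values here, compound 3 `c1ccc(-c2ccsc2)c(OCC2=NCCN2)c1` reaches 98% in a functional assay with Alpha-1A adrenergic receptor (Homo sapiens) as the target, read by calcium flux (on this read-out higher numbers stand for larger maximal responses and lower numbers for smaller maximal responses), the second highest of the three numbers measured so far. Compound 2 `c1csc(-c2ccccc2OCC2=NCCN2)c1` gives 101% in this assay, and compound 1 `Cc1cccc(-c2ccccc2OCC2=NCCN2)n1` gives 80%. Within the data shown here, the one measured step between neighbouring structures, a number 3 percentage points lower from compound 2 to compound 3 (within the scatter), stays within the usual scatter. Compound 4 `Cc1cnsc1-c1ccccc1OCC1=NCCN1` has not been measured yet; it differs from compound 3 by 4-methyl-1,2-thiazol-5-yl in place of thiophen-3-yl on an aromatic carbon. Among the measured compounds shown here, only that single step bears on exchanging one five-membered ring for another, and it was small; no measured step covers a ring with two hetero atoms, so the data give no firm direction. The expected change is therefore a number 5 percentage points lower from compound 3 to compound 4 (within the scatter), not beyond the scatter. Compound 4 is estimated to give 93%, with a range from 78% to 105%.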

Compound 4, largest response reached (reported as maximum), in percent of the reference or control that the assay uses: 104%
Estimate against measurement, compound 4: 11 percentage points below, and the stated range covers the measured number.
By their numbers in this assay, from the lowest: compound 1; then compounds 3, 2 and 4 (each within the scatter of the next).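

In this assay the 4-methyl-1,2-thiazol-5-yl ring gives a number 6 percentage points higher from compound 3 to compound 4 (within the scatter) and a number 3 percentage points higher from compound 2 to compound 4 (within the scatter) against the two thiophene rings. On this aromatic carbon, then, a five-membered ring with 2 hetero atoms and a methyl group keeps the maximal response within the scatter of both thiophenes, which the swap between thiophenes alone could not show. The data give no explanation for this result.

Still open, on these data alone, is whether the ring nitrogen or the methyl group alone would give the same response. Also open, as far as these compounds go, is how an amine or a carboxylic acid on this carbon would behave.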